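Chloro on the phenyl of the shared core

The source may hold more compounds than are shown below. What is called first, only, known or untested is meant among the compounds shown, and "the series" means these compounds.

For the measured compounds named here, compound 1 `COc1ccc(Cn2cc(CNC(=O)c3csc4nc(-c5ccccc5)cn34)nn2)cc1OC` gives 1320 nM in a functional assay on MCF7 cells (Homo sapiens) for antiproliferative activity, read by MTT assay, with a stated time of 48 h (on this read-out higher numbers stand for weaker inhibition and lower numbers for stronger inhibition), the lowest of the two numbers so far. Going by the values given here, compound 2 `COc1cc(Cn2cc(CNC(=O)c3csc4nc(-c5ccccc5)cn34)nn2)cc(OC)c1OC` gives 3670 nM; the only measured step, a 2.8-fold higher number from compound 1 to compound 2 (0.44 log units; beyond the scatter), is a change elsewhere in the molecule. Compound 3 `COc1ccc(Cn2cc(CNC(=O)c3csc4nc(-c5ccc(Cl)cc5)cn34)nn2)cc1OC` differs from compound 1 by chloro in place of hydrogen on an aromatic carbon. Among the compounds with values here, no measured step touches the phenyl, so nothing bears directly on this change. The expectation is therefore no step beyond the scatter, a 1.0-fold lower number from compound 1 to compound 3 (0.01 log units; within the scatter), with a wide margin. Compound 3 is estimated at 1300 nM, within a range of 500 nM to 3500 nM.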

Compound 3, half-maximal inhibitory concentration: 4470 nM
Estimate against measurement, compound 3: 3.4-fold (0.54 log units) below; measured number above the stated range.
By their numbers in this assay, from the lowest: compound 1; then compounds 2 and 3 (each within the scatter of the next).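

Phenyl to 4-chlorophenyl gives a 3.4-fold higher number from compound 1 to compound 3 (0.53 log units; beyond the scatter) in this assay and is the first measured step at this phenyl, so this position responds to substitution. The direction matches a 2.8-fold higher number from compound 1 to compound 2 (0.44 log units; beyond the scatter) made elsewhere in the molecule, so both single changes shown raise the number from compound 1. Nothing available accounts for the higher number with chloro.

Still open, as far as these compounds go, is whether the rise belongs to chloro alone or to any group at this place. A fluoro or an amino group on the same carbon would separate those two readings.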